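Fluoro for Methoxy in a Weakly Antiproliferative Pair

The source may report more compounds than this note shows. Statements on the series, on what has been measured and on what is new or still open speak of the compounds shown alone.

Compound 1 `Cn1c(N2N=C(c3ccccc3)CC2c2ccc(Cl)cc2)nc(-c2ccc(Cl)cc2)c(C#N)c1=O` gives 15000 nM in a functional assay on HT-29 cells (Homo sapiens) for antiproliferative activity, with a stated time of 72 h; a higher number here means a weaker inhibitor, a lower number a stronger inhibitor. Compound 2 `COc1ccc(C2CC(c3ccccc3)=NN2c2nc(-c3ccc(Cl)cc3)c(C#N)c(=O)n2C)cc1` gives 11000 nM in this assay.

Compound 2 stands beside compound 1, the two numbers lying within the scatter of each other: a 1.4-fold lower number from compound 1 to compound 2 (0.13 log units; within the scatter). Compound 3 `Cn1c(N2N=C(c3ccccc3)CC2c2ccc(F)cc2)nc(-c2ccc(Cl)cc2)c(C#N)c1=O` differs from compound 2 by fluoro in place of methoxy on an aromatic carbon. For the measured compounds named here, the only measured step bearing on this change, that from compound 1 to compound 2, also swapped a single group on that aromatic carbon and stayed within the scatter, so no step beyond the scatter is expected here either. Compound 3 is therefore estimated at 13000 nM, with a range from 6000 nM to 30000 nM. That amounts to an expected step of a 1.2-fold higher number from compound 2 to compound 3 (0.07 log units; within the scatter).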

Compound 3, half-maximal inhibitory concentration: 13700 nM
Compound 3: the middle estimate sits 1.1-fold (0.02 log units) below what was measured, within the range that was stated.
By their numbers in this assay, from the lowest: compounds 2, 3 and 1 (each within the scatter of the next).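

With compound 3, the group para to a large group on this aromatic ring has now been chloro, methoxy and fluoro, and in this assay the three compounds remain within the scatter of one another. The exchange of methoxy for fluoro gives no step beyond the scatter (a 1.2-fold higher number from compound 2 to compound 3 (0.10 log units; within the scatter)), and neither does the exchange of chloro for fluoro (a 1.1-fold lower number from compound 1 to compound 3 (0.04 log units; within the scatter)). No measured finding accounts for this result.

The compounds shown leave open whether an amine, a carboxylic acid or a longer chain at this position would give a step beyond the scatter. They also leave open whether any change elsewhere on the shared core would do so.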